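The source may hold more compounds than are shown below. What is called first, only, known or untested is meant among the compounds shown, and "the series" means these compounds.

Series notes. Three analogues of the shared core have been measured in a functional assay for inhibition, with Rattus norvegicus as the target; a higher number here means a weaker inhibitor, a lower number a stronger inhibitor. Compound 1 `CC(C)C/N=c1\c(O)c(O)\c1=N/Cc1ccc(C#N)cc1` gives 10200 nM and stands highest of the three numbers. Compound 2 `CC(/N=c1\c(O)c(O)\c1=N/[C@H](C)C(C)(C)C)c1ccc(C#N)cc1` gives 6500 nM, a number within the scatter of compound 1. Compound 3 `CC(C)(C)/N=c1\c(O)c(O)\c1=N/Cc1ccc(F)cc1` gives 1500 nM, lower than compound 1 by a margin beyond the scatter; compound 3 differs from compound 1 in more than one place, so no single change can be read from that pair.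

Compound 4 `CCCC/N=c1\c(O)c(O)\c1=N/Cc1ccc(C#N)cc1` has not yet been measured in this assay. It differs from compound 1 in one place: propyl in place of isopropyl on a saturated chain carbon bound to a double-bonded nitrogen. Among the measured compounds shown here, no pair of measured compounds shows this exchange of chains alone, and the measured compounds give no way to separate it from the other differences between them. The step is therefore expected to be small, a 1.1-fold higher number from compound 1 to compound 4 (0.03 log units; within the scatter), with no direction beyond the scatter. For compound 4 in this assay the estimate is 11000 nM, with a range from 4500 nM to 27000 nM.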

Compound 4, half-maximal inhibitory concentration: > 30000 nM
Compound 4 was reported as a limit; the forecaster's own chance of this, stated with the estimate: 10%; middle value at least 2.7-fold (0.43 log units) away from the limit.
By their numbers in this assay, from the lowest: compound 3; then compounds 2 and 1 (each within the scatter of the next). At a limit, above all of these: compound 4.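

Compound 4 gives > 30000 nM in this assay, which is a limit and not a number. Propyl in place of isopropyl on a saturated chain carbon bound to a double-bonded nitrogen gives an at least 2.9-fold higher number from compound 1 to compound 4 (0.46 log units; beyond the scatter), the first single-place comparison in the series, and it shows that this position does not treat the two chains alike even though they hold the same atoms, joined differently. The full size of this step cannot be read, since it rests on a limit: the limit of > 30000 nM in this assay, at which 1 of the 4 values shown sits.

Open, from the compounds shown here alone, is how a longer chain such as pentyl, or a chain ending in an amine or a carboxylic acid, would read at this place. Also open, going by these compounds, is whether the same exchange of chains gives a step of similar size when the nitrile is replaced by another group.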